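Nitro for Hydrogen on the Phenyl Ring of Compound 2

This account rests on a few compounds, and the source may have more. Where it says the series, first, only, none or still open, it means among the compounds named here.

Going by the values given here, in a functional assay on A549 cells (Homo sapiens) for inhibition, read by MTT assay, with a stated time of 72 h (a lower number here means a stronger inhibitor, a higher number a weaker inhibitor), compound 2 `CCN1C(=O)N(CC)C2C1NC(=O)N2/N=C/C=C/c1ccccc1` gives 44300 nM, the highest of the two numbers measured so far. Its nearest neighbour, compound 1 `CCN1C(=O)N(CC)C2C1N=C(SC)N2/N=C/C=C/c1ccccc1`, gives 21400 nM, a gap beyond the usual scatter. Compound 3 `CCN1C(=O)N(CC)C2C1NC(=O)N2/N=C/C=C/c1ccccc1[N+](=O)[O-]` differs from compound 2 by nitro in place of hydrogen on an aromatic carbon, phenyl to 2-nitrophenyl. Among the compounds with values here, no measured pair shows this change, so the expected step of a 1.2-fold lower number from compound 2 to compound 3 (0.07 log units; within the scatter) is small, in either direction, and not beyond the scatter. Compound 3 is therefore estimated at 38000 nM, with a range from 12000 nM to 110000 nM.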

Compound 3, half-maximal inhibitory concentration: > 100000 nM
Compound 3 was reported as a limit (the forecaster's own chance of this, stated with the estimate: 20%); at least 2.6-fold (0.42 log units) between middle value and limit.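

In this assay, the change from phenyl to 2-nitrophenyl gives an at least 2.2-fold higher number from compound 2 to compound 3 (0.35 log units; beyond the scatter), the first sign that this aromatic carbon is not indifferent to what it carries: nitro here shifts the number towards weaker inhibition, beyond the scatter. Compound 3 gives > 100000 nM, which is a limit of the assay and not a number: the limit of > 100000 nM in this assay, at which 1 of the 3 values shown sits.

The compounds shown leave open whether an amine or a methoxy group on this carbon would shift the number the same way. From the compounds shown here alone, whether nitro on the phenyl ring of compound 1 would do so also remains open.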